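Replacing the amino group on the shared core

A few compounds are considered here, and "the series" means these few. Any claim that something is new, unique, unknown or untested is made for them only; others in the source may bear on it.

- compound 1 `CN1Cc2sc(Br)cc2C(c2ccc(Br)cc2)C1` gives 1600 nM in this series
- compound 2 `CN1Cc2sc(N)cc2C(c2ccc(Br)cc2)C1` gives 130 nM in this series

In a functional assay (synaptosomes, brain) for inhibition, with Rattus norvegicus as the target (on this read-out lower numbers stand for stronger inhibition and higher numbers for weaker inhibition), compound 2 holds the lower of the two numbers, at 130 nM so far. Compound 3 `COCc1cc2c(s1)CN(C)CC2c1ccc(Br)cc1` departs from compound 2 by methoxymethyl in place of amino on an aromatic carbon with methoxymethyl in place of amino on an aromatic carbon. For the measured compounds named here, the only measured step at this carbon, amino in place of bromo, is large, with a 12-fold lower number from compound 1 to compound 2 (1.09 log units; beyond the scatter) as its size. That step shows this place responds but says nothing directly about methoxymethyl. A moderate rise beyond the scatter is therefore expected in this assay and is estimated as a 3.5-fold higher number from compound 2 to compound 3 (0.54 log units; beyond the scatter) for now. For compound 3 the expected value is 450 nM within an estimated range of 120 nM to 1600 nM pending measurement.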

Compound 3, half-maximal inhibitory concentration: 370 nM
The estimate for compound 3 lay 1.2-fold (0.09 log units) above the measured number, within the range that was stated.
By their numbers in this assay, from the lowest: compound 2; then compound 3; then compound 1.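

In this assay, replacing amino with methoxymethyl at this carbon gives a 2.8-fold higher number from compound 2 to compound 3 (0.45 log units; beyond the scatter), while replacing bromo with methoxymethyl gives a 4.3-fold lower number from compound 1 to compound 3 (0.64 log units; beyond the scatter). Compound 3 therefore places methoxymethyl in the middle of the three groups, showing that a lower number than that of compound 1 does not require amino, since methoxymethyl has 0 hydrogen-bond donors. No available data explain this order.

Still open, from the compounds shown here alone, is whether a methylamino or dimethylamino group here would keep the number of compound 2. A longer ether chain such as ethoxymethyl, or a carboxylic acid, also remains untested in the compounds shown.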